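Methoxy in place of ethyl: working notes

A few compounds are considered here, and "the series" means these few. Any claim that something is new, unique, unknown or untested is made for them only; others in the source may bear on it.

Measured in a functional assay on MDA-MB-231 cells (Homo sapiens) for inhibition, read by CCK-8 assay, with a stated time of 48 h; a lower number here means a stronger inhibitor of growth, a higher number a weaker inhibitor of growth:
- compound 1 `CN1CCN(c2ccc(Nc3ncc(Cl)c(NCc4ccco4)n3)nc2)CC1`: 11000 nM
- compound 2 `Cc1ccc(Nc2nc(Nc3ccc(N4CCN(C)CC4)cn3)ncc2Cl)cc1`: 4030 nM
- compound 3 `CCc1ccc(Nc2nc(Nc3ccc(N4CCN(C)CC4)cn3)ncc2Cl)cc1`: 5560 nM

Compound 3 at 5560 nM lies within the scatter of both other compounds, as shown by a 1.4-fold higher number from compound 2 to compound 3 (0.14 log units; within the scatter) and by a 2.0-fold lower number from compound 1 to compound 3 (0.30 log units; within the scatter). Among the compounds with values here, the only step beyond the scatter is the modest 2.7-fold lower number from compound 1 to compound 2 (0.44 log units; beyond the scatter).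

Next comes compound 4 `COc1ccc(Nc2nc(Nc3ccc(N4CCN(C)CC4)cn3)ncc2Cl)cc1`, which carries methoxy in place of ethyl on an aromatic carbon, para to a large group (methoxy in place of ethyl on an aromatic carbon). The closest evidence is the change from 4-methylphenyl to 4-ethylphenyl, a 1.4-fold higher number from compound 2 to compound 3 (0.14 log units; within the scatter), which stays within the scatter. The two steps away from (furan-2-yl)methyl replace a different group and bear on this change only loosely. Within the data shown here, no measured compound carries methoxy, so the direction remains open, and no shift beyond the scatter is expected in this assay. The expected change is a 1.1-fold lower number from compound 3 to compound 4 (0.05 log units; within the scatter). For compound 4 the estimated value is 5000 nM, with an expected range of 2400 nM to 10000 nM.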

Compound 4, concentration for 50% growth inhibition: 8020 nM
Beside the measured number, compound 4's estimate is 1.6-fold (0.21 log units) below it; measured number inside the range.
By their numbers in this assay, from the lowest: compounds 2, 3, 4 and 1 (each within the scatter of the next, the first and the last beyond it).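

In this assay, methoxy on this aromatic carbon, with its one hydrogen-bond acceptor, gives no step beyond the scatter from either alkyl group (a 1.4-fold higher number from compound 3 to compound 4 (0.16 log units; within the scatter); a 2.0-fold higher number from compound 2 to compound 4 (0.30 log units; within the scatter)). Within the data shown here, compound 4 also stays within the scatter of the (furan-2-yl)methyl compound (a 1.4-fold lower number from compound 1 to compound 4 (0.14 log units; within the scatter)), so 4-methoxyphenyl does not share the single step beyond the scatter in this set, the one printed for 4-methylphenyl. No measurement bears on the reason for any of these steps.

Going by these compounds, whether an amine, a carboxylic acid or a longer chain on this aromatic carbon would give a step beyond the scatter from the methyl, ethyl and methoxy compounds stays open. Also open, on these data alone, is how a halogen such as fluorine or chlorine at this place would compare with methoxy.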